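A few compounds are considered here, and "the series" means these few. Any claim that something is new, unique, unknown or untested is made for them only; others in the source may bear on it.

Three compounds that share one core and differ only in the phenyl group on a nitrogen show how sensitive growth inhibition is to that group. Among the measured compounds shown here, in a functional assay on HeLa cells (Homo sapiens) for antiproliferative activity, read by spectrophotometry, with a stated time of 2 days (a higher number here means a weaker inhibitor of growth, a lower number a stronger inhibitor of growth), compound 3, `Cc1cc(F)ccc1Nc1ncc(C(F)(F)F)c(N2Cc3cccc(N(C)S(C)(=O)=O)c3C2)n1`, gives 6500 nM, the lowest number so far. Compound 1, `COc1ccc(Nc2ncc(C(F)(F)F)c(N3Cc4cccc(N(C)S(C)(=O)=O)c4C3)n2)cc1C(F)(F)F`, gives 14000 nM. Compound 2, `Cc1ccc(Nc2ncc(C(F)(F)F)c(N3Cc4cccc(N(C)S(C)(=O)=O)c4C3)n2)cc1C`, reaches only a limit of the assay, > 30000 nM.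

Compound 4, `CN(c1cccc2c1CN(c1nc(Nc3ccc(C(F)(F)F)cc3)ncc1C(F)(F)F)C2)S(C)(=O)=O`, has 4-(trifluoromethyl)phenyl in place of 4-fluoro-2-methylphenyl on a nitrogen on an aromatic ring.

Two measured changes at this same place bear on it, and both show the group of compound 3 doing better: a 2.2-fold lower number from compound 1 to compound 3 (0.33 log units; beyond the scatter) and an at least 4.6-fold lower number from compound 2 to compound 3 (0.66 log units; beyond the scatter). The phenyl group of compound 1 also carries a trifluoromethyl, so the step to that compound is the closest guide, with 14000 nM as its value. A modest rise in this assay is therefore expected, estimated as a 2.0-fold higher number from compound 3 to compound 4 (0.30 log units; within the scatter). For compound 4 the estimate is 13000 nM, with an expected range of 5000 nM to 32000 nM.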

Compound 4, concentration for 50% growth inhibition: > 30000 nM
Compound 4: only a limit was reported; the forecaster's own chance of this, stated with the estimate: 25%; middle value at least 2.3-fold (0.36 log units) away from the limit.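

In this assay, 4-(trifluoromethyl)phenyl is a poor replacement at this nitrogen, with an at least 4.6-fold higher number from compound 3 to compound 4 (0.66 log units; beyond the scatter). The earlier compounds shown here could not show that a trifluoromethyl group on the phenyl ring does not by itself decide the result: 4-methoxy-3-(trifluoromethyl)phenyl also carries one, yet there is an at least 2.1-fold higher number from compound 1 to compound 4 (0.33 log units; beyond the scatter). Compound 4 joins compound 2 at a limit of the assay, not a true number, so the step between them cannot be read: the limit of > 30000 nM in this assay, at which 2 of the 4 values shown sit.

On these data alone, how far compound 4 lies past its limit stays open, so both readable steps give only a minimum size. Also open, as far as these compounds go, is whether a phenyl group carrying an amine or a carboxylic acid would give a lower number than compound 3 does.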